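A few compounds are considered here, and "the series" means these few. Any claim that something is new, unique, unknown or untested is made for them only; others in the source may bear on it.

Measured so far:
Compound 1 `CCNC(=O)c1oc2nc(-c3cccs3)cc(C(F)(F)F)c2c1N`: 62000 nM
Compound 2 `Nc1c(C(=O)NC2CCCC2)oc2nc(-c3cccs3)cc(C(F)(F)F)c12`: 51000 nM

Both were tested in an ADME assay on HEK293 cells (Homo sapiens) for antiproliferative activity, read by MTT assay; on this read-out higher numbers stand for weaker inhibition and lower numbers for stronger inhibition. In this assay compound 1 gives 62000 nM, and compound 2 gives 51000 nM. The step between them, a 1.2-fold lower number from compound 1 to compound 2 (0.08 log units; within the scatter), lies within the scatter, so compound 2 stands level with compound 1 rather than apart from it.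

Compound 3 `Cc1ccc(/C=N/NC(=O)c2oc3nc(-c4cccs4)cc(C(F)(F)F)c3c2N)cc1` has not yet been measured. It differs from compound 2 by a group of 9 heavy atoms (8 carbon, 1 nitrogen; one six-membered aromatic ring of carbon only) in place of a group of 5 heavy atoms (5 carbon; one five-membered non-aromatic ring of carbon only), on an amide-type nitrogen. Among the measured compounds shown here, the only measured step available, a 1.2-fold lower number from compound 1 to compound 2 (0.08 log units; within the scatter), also swapped the group on this amide-type nitrogen and produced no change beyond the scatter. The change to compound 3 is larger and brings in a group of a different kind, so that step gives no firm direction. A modest step toward a lower number, a 1.7-fold lower number from compound 2 to compound 3 (0.23 log units; within the scatter), is expected, with wide uncertainty. Compound 3 is therefore estimated at 30000 nM, in the range 8000 nM to 100000 nM.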

Compound 3, half-maximal inhibitory concentration: 78000 nM
The estimate for compound 3 lay 2.6-fold (0.41 log units) below the measured number, within the range that was stated.
By their numbers in this assay, from the lowest: compounds 2, 1 and 3 (each within the scatter of the next).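

In this assay, the group on the amide-type nitrogen now carries a six-membered aromatic ring of carbon and a double bond outside aromatic rings, a different kind of group from ethyl or cyclopentyl, yet a 1.5-fold higher number from compound 2 to compound 3 (0.18 log units; within the scatter) and a 1.3-fold higher number from compound 1 to compound 3 (0.10 log units; within the scatter) both lie within the scatter. Compounds 1 and 2 had shown this only for two groups made of carbon alone, whereas compound 3 shows that a group of 9 heavy atoms containing nitrogen also stands level with them. No measurement available here accounts for this flat result.

From the compounds shown here alone, it remains open whether another group on this nitrogen, such as a carboxylic acid or a longer chain ending in an amine, would move the number beyond the scatter. Going by these compounds, whether a change elsewhere on the shared core would do so also remains unknown.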